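One Methyl Further Along the Chain

The source may hold more compounds than are shown below. What is called first, only, known or untested is meant among the compounds shown, and "the series" means these compounds.

Compound 1 `C=C(C)C(=O)c1ccc(OCC(=O)O)cc1Cl` in a functional assay on HL-60 cells (Homo sapiens) for antiproliferative activity, with a stated time of 72 h (on this read-out higher numbers stand for weaker inhibition of growth and lower numbers for stronger inhibition of growth), gives > 60000 nM, which is a limit of the assay.
Compound 3 `C=C(CC)C(=O)c1ccc(OCC(=O)O)cc1Cl` in this assay gives > 60000 nM, likewise a limit of the assay.
Compound 2 `C=C(CCC)C(=O)c1ccc(OCC(=O)O)c(C)c1C` in this assay gives 19300 nM.

Among the measured compounds shown here, compound 2 thus stands as the only compound with an actual number on this read-out; the other two entries fall under (the limit of > 60000 nM in this assay, at which 2 of the 3 values shown sit). The step from compound 1 to compound 3 is a step that the two limits leave unreadable from compound 1 to compound 3, so it offers no size to lean on. Compound 4 `C=C(CCCC)C(=O)c1ccc(OCC(=O)O)c(C)c1C` differs from compound 2 by methyl in place of hydrogen on a saturated chain carbon, three bonds along the chain from a double-bonded chain carbon. For the measured compounds named here, no measured step with a readable size bears on this change, since the one comparable step sits between two limits. The expectation is therefore no shift beyond the scatter. Compound 4 is estimated to give 19000 nM, in a range of 8000 nM to 45000 nM. That amounts to an expected step of a 1.0-fold lower number from compound 2 to compound 4 (0.01 log units; within the scatter) in this assay.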

Compound 4, concentration for 50% growth inhibition: 14400 nM
Compound 4: the middle estimate sits 1.3-fold (0.12 log units) above what was measured; the measured number falls inside the stated range.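

In this assay, the change of propyl to butyl gives a 1.3-fold lower number from compound 2 to compound 4 (0.13 log units; within the scatter), the first readable size for methyl in place of hydrogen on this stretch of the chain. At this place, three bonds along the chain from a double-bonded chain carbon, the added methyl therefore makes no difference beyond the scatter. The earlier step from compound 1 to compound 3 cannot be read, and neither compound gives a number: the limit of > 60000 nM in this assay, at which 2 of the 4 values shown sit.

The compounds shown leave open what a pentyl chain or an amine in place of the butyl chain would give. They also leave open whether a butyl chain on the core of compound 1 would give a number at all.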